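The source may report more compounds than this note shows. Statements on the series, on what has been measured and on what is new or still open speak of the compounds shown alone.

Measured so far in an ADME assay on MIA PaCa-2 cells (Homo sapiens) for cytotoxicity, read by MTT assay, with a stated time of 72 h; a higher number here means a weaker inhibitor, a lower number a stronger inhibitor:
- compound 1 `COc1ccc(C2=C(c3cc(OC)c(OC)c(OC)c3)C(=O)C(OC(C)=O)C2)cc1Cl`: 24 ug/mL
- compound 2 `COCOc1cc(C2=C(c3cc(OC)c(OC)c(OC)c3)C(=O)CC2O[SiH2]C(C)(C)C)ccc1OC`: 50 ug/mL
- compound 3 `COc1cc(C2=C(c3cc(C)c(OC)c(C)c3)C(OC(C)=O)CC2=O)cc(OC)c1OC`: > 100 ug/mL

Compound 3 gives only a limit of this assay, > 100 ug/mL, and no number (the limit of > 100 ug/mL in this assay, at which 1 of the 3 values shown sits). Of the two numbers that remain, compound 2 holds the higher, and compound 1 the lower; the gap between them lies beyond the scatter of this assay. Going by the values given here, no pair among the three differs in a single place, so no measured step can be traced here.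

Compound 4 `COc1ccc(C2=C(c3cc(OC)c(OC)c(OC)c3)C(=O)CC2O[SiH2]C(C)(C)C)cc1` is not yet measured. It differs from compound 2 in one place: hydrogen in place of methoxymethoxy on an aromatic carbon. The methoxymethoxy group sits ortho to a methoxy group and meta to a large group on the six-membered aromatic ring of carbon only, and in compound 4 a hydrogen atom stands there instead.

Among the compounds with values here, with no measured step of this kind among the three compounds, the expected change is a modest one. For compound 4 a step of a 1.3-fold lower number from compound 2 to compound 4 (0.12 log units; within the scatter) toward a somewhat lower number is estimated, though a result within the scatter of the value of compound 2 would not surprise. Compound 4 is thus expected to give about 38 ug/mL in this assay, within a range of 15 ug/mL to 100 ug/mL.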

Compound 4, half-maximal inhibitory concentration: > 100 ug/mL
Compound 4 was reported as a limit; the forecaster's own chance of this, stated with the estimate: 20%; middle value at least 2.6-fold (0.42 log units) from the limit.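

In this assay, going by these compounds alone, the change from 4-methoxy-3-(methoxymethoxy)phenyl to 4-methoxyphenyl gives the first step that can be read at this place: an at least 2.0-fold higher number from compound 2 to compound 4 (0.30 log units; that floor lies within the scatter). The step therefore has a direction but only a floor for its size, so the data show that hydrogen on this aromatic carbon, ortho to a methoxy group, does not bring a lower number than methoxymethoxy, while they do not show a rise beyond the scatter. Compound 4 gives > 100 ug/mL, which is a limit of the assay and not a number, and it shares that limit with one other compound: the limit of > 100 ug/mL in this assay, at which 2 of the 4 values shown sit.

The compounds shown leave open how large the step really is, and whether a hydroxyl group or an amine on this same aromatic carbon would give a number rather than a limit. They also leave open whether the change from methoxymethoxy to hydrogen would read the same way in a compound carrying the acetoxy group of compound 1.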